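Removing the 2-Carboxyethyl Chain from Two Related Cores

This account rests on a few compounds, and the source may have more. Where it says the series, first, only, none or still open, it means among the compounds named here.

Compound 1 `Cn1nc(Cc2nnc(SCCCCCCCC(=O)Nc3ccc(Cl)cc3Cl)[nH]2)c2ccccc2c1=O`, compound 2 `Cn1nc(Cc2nnc(SCCCCCCCC(=O)Nc3ccc(Cl)cc3Cl)n2CCC(=O)O)c2ccccc2c1=O` and compound 3 `Cn1c(Cc2nn(CCC(=O)O)c(=O)c3ccccc23)nnc1SCCCCCCCC(=O)Nc1ccc(Cl)cc1Cl` were tested in an assay on NK92 cells for inhibition of interleukin-2 (Homo sapiens), read by AlphaScreen, with stated times of 30 min and 1 h; a lower number here means a stronger inhibitor, a higher number a weaker inhibitor. Compound 1 gives 450 nM, compound 2 gives 14300 nM and compound 3 gives 30000 nM. Compound 2 and compound 3 share the same atoms joined differently; the difference between the two cores is not broken down here. Compound 1 differs from compound 2 by a single change, (hydrogen in place of 2-carboxyethyl on an aromatic nitrogen), and that change gave a 32-fold lower number from compound 2 to compound 1 (1.50 log units; beyond the scatter). Compound 4 `Cn1c(Cc2n[nH]c(=O)c3ccccc23)nnc1SCCCCCCCC(=O)Nc1ccc(Cl)cc1Cl` has not yet been measured; it differs from compound 3 by hydrogen in place of 2-carboxyethyl on an aromatic nitrogen. This is the same kind of change, but at a different place: in compound 2 the chain sat on an aromatic nitrogen of a five-membered aromatic ring with 3 nitrogen, next to two ring atoms that each bear a large group, whereas in compound 3 it sits on an aromatic nitrogen of a six-membered aromatic ring with 2 nitrogen, part of a fused or bridged system of two rings, next to the ring nitrogen. Because the same kind of change gave a 32-fold lower number from compound 2 to compound 1 (1.50 log units; beyond the scatter), a step in the same direction is expected, namely a 17-fold lower number from compound 3 to compound 4 (1.22 log units; beyond the scatter), tempered for the different place. Compound 4 is estimated at 1800 nM, expected between 400 nM and 9000 nM.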

Compound 4, half-maximal inhibitory concentration: > 30000 nM
Compound 4 was reported as a limit; the forecaster's own chance of this, stated with the estimate: 5%; middle value at least 16-fold (1.22 log units) from the limit.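

In this assay compound 4 gives > 30000 nM as a limit of the assay and not as a number. Hydrogen in place of 2-carboxyethyl on an aromatic nitrogen gave a number no lower from compound 3 to compound 4 (the limit leaves the size open), so this change did not carry over from one core to the other with the same result, and the two steps differ: the same change on two cores in this assay, a 32-fold lower number (1.50 log units; beyond the scatter) from compound 2 to compound 1 and a number no lower (the limit leaves the size open) from compound 3 to compound 4, at least 31-fold (1.50 log units) apart, beyond the scatter of two such steps. This does not show how far compound 4 lies from compound 3, or what separates the two places, since the reading stops at the limit: the limit of > 30000 nM in this assay, at which 1 of the 4 values shown sits.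

The compounds shown leave open whether an amine in place of the carboxylic acid, or a shorter chain ending in the carboxylic acid, on this ring nitrogen would bring the number down on the core of compound 3. They also leave open whether a methyl group there would behave like the hydrogen of compound 4.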